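A few compounds are considered here, and "the series" means these few. Any claim that something is new, unique, unknown or untested is made for them only; others in the source may bear on it.

Measured compounds:
compound 1 `Cc1cccc(-c2noc([C@@H](C)NC(=O)c3cc(C4CC4)nn3C)n2)c1` with 3310 nM
compound 2 `Cc1cncc(-c2noc([C@H](C)NC(=O)c3cc(C(F)(F)F)nn3C)n2)c1` with 1370 nM

In an assay on T-REx-293 cells for inhibition of potassium channel subfamily T member 1 (Homo sapiens), read by patch clamp (on this read-out lower numbers stand for stronger inhibition and higher numbers for weaker inhibition), compound 2 gives 1370 nM, the lower of the two numbers. Its nearest neighbour is compound 1, which in this assay gives 3310 nM, a gap beyond the usual scatter, so compound 2 shows the stronger inhibition of the pair.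

Compound 3 `CO[C@H](C)c1cc(-c2noc([C@H](C)NC(=O)c3cc(C(F)(F)F)nn3C)n2)ccn1` has not yet been measured. It differs from compound 2 by a group of 10 heavy atoms (8 carbon, 1 nitrogen, 1 oxygen; one six-membered aromatic ring with 1 hetero atom) in place of a group of 7 heavy atoms (6 carbon, 1 nitrogen; one six-membered aromatic ring with 1 hetero atom), on an aromatic carbon. Among the compounds with values here, no step between measured compounds is known that would bear on this change, so the expectation rests on the value of compound 2 alone. The group that enters is larger and carries one more hydrogen-bond acceptor; no comparable change is available, so a step close to none beyond the scatter is expected, with considerable uncertainty. Compound 3 is therefore expected to give about 1000 nM, with a likely range from 300 nM to 4000 nM, which is estimated as a step of a 1.4-fold lower number from compound 2 to compound 3 (0.14 log units; within the scatter).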

Compound 3, half-maximal inhibitory concentration: 778 nM
For compound 3 the middle estimate is 1.3-fold (0.11 log units) above the measured one; low and high end bracket the measured number.
By their numbers in this assay, from the lowest: compounds 3 and 2 (each within the scatter of the next); then compound 1.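

In this assay, placing the larger group on an aromatic carbon, in place of 5-methylpyridin-3-yl, gives a 1.8-fold lower number from compound 2 to compound 3 (0.25 log units; within the scatter). This position therefore accommodates a group of 10 heavy atoms with 2 hydrogen-bond acceptors and a defined stereocentre without a step beyond the scatter, which compounds 1 and 2, differing in more than one place, could not show. No measurement at hand bears on the reason for this result.

The compounds shown leave open whether the oxygen of the entering group or its defined stereocentre matters for the number in this assay. They also leave open how a primary amine or a carboxylic acid on that pyridine ring would read.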